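The source may hold more compounds than are shown below. What is called first, only, known or untested is meant among the compounds shown, and "the series" means these compounds.

In a functional assay on CCRF-CEM cells (Homo sapiens) for inhibition, read by MTT assay, with a stated time of 72 h (a lower number here means a stronger inhibitor, a higher number a weaker inhibitor), compound 1 (`COc1cc(NC(C)CCCNC(=O)Nc2cccc(Cl)c2)c2ncccc2c1`) gives 22000 nM. For the measured compounds named here, compound 2 (`COc1cc(NC(C)CCCNC(=O)Nc2cc(C(F)(F)F)cc(C(F)(F)F)c2)c2ncccc2c1`) gives 4100 nM, the lower of the two numbers so far. The gap between these two compounds lies beyond the scatter. Compound 3 (`COc1cc(NC(C)CCCNC(=O)Nc2cccc(C(F)(F)F)c2)c2ncccc2c1`) carries hydrogen in place of trifluoromethyl on an aromatic carbon. Going by the values given here, no measured pair differs in one place only, so the expectation rests on these two values alone. A higher number beyond the scatter is expected. The expected move is towards compound 1 at 22000 nM. The expected size is a 2.7-fold higher number from compound 2 to compound 3 (0.43 log units; beyond the scatter). For compound 3 the estimated value is 11000 nM, with an expected range of 5500 nM to 22000 nM.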

Compound 3, half-maximal inhibitory concentration: 19000 nM
Beside the measured number, compound 3's estimate is 1.7-fold (0.24 log units) below it, within the range that was stated.
By their numbers in this assay, from the lowest: compound 2; then compounds 3 and 1 (each within the scatter of the next).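

In this assay, hydrogen in place of trifluoromethyl on an aromatic carbon gives a 4.6-fold higher number from compound 2 to compound 3 (0.67 log units; beyond the scatter), so this position responds to the change and the second trifluoromethyl matters in this series. Trifluoromethyl in place of chloro on an aromatic carbon gives a 1.2-fold lower number from compound 1 to compound 3 (0.06 log units; within the scatter), which stays within the scatter. Nothing available bears on the reason for either step.

As far as these compounds go, it remains open how an amine or a carboxylic acid in place of trifluoromethyl on that aromatic carbon would read against compound 2 at 4100 nM. From the compounds shown here alone, the effect of a longer chain on the shared core also remains open.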